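Replacing 4-methoxyphenyl with 2-methylphenyl in compound 3

A few compounds are considered here, and "the series" means these few. Any claim that something is new, unique, unknown or untested is made for them only; others in the source may bear on it.

Compound 1 `Cc1ccc2c(O)nc(-c3ccccc3C)cc2c1` gives 30900 nM
Compound 2 `Cc1ccc2c(S)nc(-c3ccccc3)cc2c1` gives 19100 nM; 41900 nM (2 entries)
Compound 3 `COc1ccc(-c2cc3cc(C)ccc3c(N3CCN(C)CC3)n2)cc1` gives 9330 nM

In a functional assay on HCT-15 cells (Homo sapiens) for cytotoxicity (a lower number here means a stronger inhibitor, a higher number a weaker inhibitor), compound 3 has the lowest single number (9330 nM), and compound 1 stands nearest, higher by more than the scatter. Compound 2 has no single number, only separate entries (the several entries of compound 2 in this assay, 19100 nM; 41900 nM (2 entries)). Compound 4 `Cc1ccc2c(N3CCN(C)CC3)nc(-c3ccccc3C)cc2c1` keeps the 4-methylpiperazin-1-yl group of compound 3 but carries 2-methylphenyl in place of 4-methoxyphenyl on an aromatic carbon. Within the data shown here, no measured pair isolates this exchange. A small upward move within the scatter is expected, the estimated change being a 1.3-fold higher number from compound 3 to compound 4 (0.11 log units; within the scatter) in this assay. The expected value for compound 4 is 12000 nM (estimated range 4500 nM to 30000 nM).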

Compound 4, half-maximal inhibitory concentration: 77600 nM
Estimate against measurement, compound 4: 6.5-fold (0.81 log units) below; measured number above the stated range.
By their numbers in this assay, from the lowest: compound 3; then compound 1; then compound 4.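

In this assay, the carbon next to the ring nitrogen is sensitive to the aryl group it carries: 2-methylphenyl in place of 4-methoxyphenyl gives an 8.3-fold higher number from compound 3 to compound 4 (0.92 log units; beyond the scatter). With 2-methylphenyl held fixed, 4-methylpiperazin-1-yl in place of hydroxy gives a 2.5-fold higher number from compound 1 to compound 4 (0.40 log units; beyond the scatter), so this group does not by itself bring the lower number seen for compound 3. Nothing in the data explains either step.

The compounds shown leave open whether the step follows the identity of the substituent on the phenyl ring or its place. A 4-methylphenyl or 2-methoxyphenyl group at this carbon would separate the two.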